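A few compounds are considered here, and "the series" means these few. Any claim that something is new, unique, unknown or untested is made for them only; others in the source may bear on it.

In a functional assay on C8166 cells (Homo sapiens) for cytotoxicity, read by MTT assay (on this read-out higher numbers stand for lower toxicity in this test and lower numbers for higher toxicity in this test), compound 1 `Cc1cc(S(N)(=O)=O)ccc1NC(=O)COc1ccc(Cl)cc1NC(=O)c1ccccc1` gives 207000 nM and compound 2 `Cc1cc(S(N)(=O)=O)ccc1NC(=O)COc1ccc(Cl)cc1NC(=O)c1cc(Cl)cc(C#N)c1` gives 131000 nM as its value, so these two sit within the usual scatter of each other. Compound 3 `Cc1cc(S(N)(=O)=O)ccc1NC(=O)COc1ccc(Cl)cc1NC(=O)/C=C/c1ccccc1` is not yet measured and differs from compound 2 by 2-phenylethenyl in place of 3-chloro-5-cyanophenyl on a carbonyl carbon in one place: 2-phenylethenyl in place of 3-chloro-5-cyanophenyl on a carbonyl carbon. Among the measured compounds shown here, the only measured step at this place is a 1.6-fold lower number from compound 1 to compound 2 (0.20 log units; within the scatter) and it stayed within the scatter, so no change beyond the scatter is expected. The expected change is a 1.1-fold higher number from compound 2 to compound 3 (0.06 log units; within the scatter) by this estimate. For compound 3 the estimated value is 150000 nM with an expected range from 65000 nM to 340000 nM for repeated measurements.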

Compound 3, half-maximal cytotoxic concentration: 163000 nM
Estimate against measurement, compound 3: 1.1-fold (0.04 log units) below; the measured number falls inside the stated range.
By their numbers in this assay, from the lowest: compounds 2, 3 and 1 (each within the scatter of the next).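

With 2-phenylethenyl on the carbonyl carbon, a double bond outside the aromatic ring enters this position, and this assay shows a 1.2-fold higher number from compound 2 to compound 3 (0.09 log units; within the scatter) and a 1.3-fold lower number from compound 1 to compound 3 (0.10 log units; within the scatter). Phenyl, 3-chloro-5-cyanophenyl and 2-phenylethenyl therefore cannot be told apart here, whether the group on the carbonyl carbon is an aromatic ring directly or is connected through a double bond. No measurement shown offers an explanation for this result. Still open, going by these compounds, is whether a group without an aromatic ring, such as an amine, a carboxylic acid or a longer saturated carbon chain, would give a number beyond the scatter at this position.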